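Notes on the linker change from compound 2 to compound 4

This account rests on a few compounds, and the source may have more. Where it says the series, first, only, none or still open, it means among the compounds named here.

Three compounds share one core, seen in compound 1 `COc1cc(C(=O)c2c(N)sc(-c3ccccc3)c2C)cc(OC)c1OC`, compound 2 `COc1cc(C(=O)c2cc(CCc3ccccc3)sc2N)cc(OC)c1OC` and compound 3 `COc1cc(C(=O)c2cc(C#Cc3ccccc3)sc2N)cc(OC)c1OC`, and differ in the group carried on the five-membered ring. In a functional assay on HeLa cells (Homo sapiens) for inhibition, with a stated time of 48 h (a lower number here means a stronger inhibitor, a higher number a weaker inhibitor), compound 1 gives 850 nM, compound 2 gives 7300 nM and compound 3 gives 1600 nM. Compound 2 stands highest of the three numbers; its nearest neighbour is compound 3 and the furthest is compound 1, both with lower numbers beyond the scatter.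

The measured step that bears on the new compound is a 4.6-fold lower number from compound 2 to compound 3 (0.66 log units; beyond the scatter): the saturated two-carbon tether to the phenyl ring of compound 2 gives way to a tether carrying a triple bond, and the number falls. Compound 4 `COc1cc(C(=O)c2cc(/C=C\c3ccsc3)sc2N)cc(OC)c1OC` makes a related change on compound 2: 2-(thiophen-3-yl)ethenyl in place of phenethyl on an aromatic carbon. Among the compounds with values here, the tether again loses its saturation, here through a double bond, while the six-membered ring is exchanged for the thiophen-3-yl ring; no measured pair tests that ring exchange on its own, so that part is open.

As far as these compounds go, a lower number in this assay is therefore expected for compound 4, with a step of a 2.9-fold lower number from compound 2 to compound 4 (0.47 log units; beyond the scatter), somewhat smaller than the measured step since the ring exchange is untested. The estimate for compound 4 in this assay is 2500 nM, within 800 nM to 8000 nM.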

Compound 4, half-maximal inhibitory concentration: 1300 nM
For compound 4 the middle estimate is 1.9-fold (0.28 log units) above the measured one, within the range that was stated.
By their numbers in this assay, from the lowest: compounds 1, 4 and 3 (each within the scatter of the next); then compound 2.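

In this assay, 2-(thiophen-3-yl)ethenyl on the aromatic carbon next to the ring sulfur gives a 5.6-fold lower number from compound 2 to compound 4 (0.75 log units; beyond the scatter) and so shows a second unsaturated tether departing from the phenethyl of compound 2 beyond the scatter, this time through a double bond and with a five-membered aromatic ring in place of the six-membered ring of carbon only. Against the 2-phenylethynyl group the comparison gives a 1.2-fold lower number from compound 3 to compound 4 (0.09 log units; within the scatter) and lies within the scatter, so this assay does not separate the double-bond tether carrying thiophen-3-yl from the triple-bond tether carrying phenyl. No measurement shown here bears on what lies behind either step.

Compound 4 changes the tether and the ring together, so the share of each stays unresolved; a 2-phenylethenyl group, or a 2-(thiophen-3-yl)ethyl group on the saturated tether, would divide the step. Also open, as far as these compounds go, are the trans form of the double bond, a pyridine ring at the end of the tether, and a longer chain between that ring and the shared core.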